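From compound 3 to compound 4: one ring exchanged

The source may report more compounds than this note shows. Statements on the series, on what has been measured and on what is new or still open speak of the compounds shown alone.

In a functional assay on AGS cells (Homo sapiens) for inhibition, read by reporter gene assay (on this read-out higher numbers stand for weaker inhibition and lower numbers for stronger inhibition), compound 1 `O=C(COc1ccc(Br)cc1)Nc1cccc(C(=O)O)c1` gives 1600 nM. Compound 2 `O=C(COc1ccc(-c2cccs2)cc1)Nc1cccc(C(=O)O)c1` gives > 30000 nM, which is a limit and not a number. Compound 3 `Cc1ccc(-c2ccc(OCC(=O)Nc3cccc(C(=O)O)c3)cc2)cc1` gives > 30000 nM, also a limit. This is the limit of > 30000 nM in this assay, at which 2 of the 3 values shown sit.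

Replacing bromo with a ring was a large change both times: an at least 18-fold higher number from compound 1 to compound 2 (1.27 log units; beyond the scatter), and an at least 18-fold higher number from compound 1 to compound 3 (1.27 log units; beyond the scatter). Exchanging one ring for another gave a step that the two limits leave unreadable from compound 2 to compound 3.

Compound 4 `COc1cccc(-c2ccc(OCC(=O)Nc3cccc(C(=O)O)c3)cc2)c1` carries 3-methoxyphenyl in place of 4-methylphenyl (3-methoxyphenyl in place of 4-methylphenyl on an aromatic carbon). Inhibition is therefore expected to stay weak, with no step beyond the scatter. The expected step is a number no higher from compound 3 to compound 4 (the limit leaves the size open). Compound 4 is estimated at 30000 nM, within an expected range of 10000 nM to 60000 nM.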

Compound 4, half-maximal inhibitory concentration: 35000 nM
Beside the measured number, compound 4's estimate is 1.2-fold (0.07 log units) below it; the range from low to high includes it.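

For the compounds shown here, this is the first compound with a ring in place of bromo at this position to give an actual number, so the loss can now be sized: a 22-fold higher number from compound 1 to compound 4 (1.34 log units; beyond the scatter). The 3-methoxyphenyl ring brings a hydrogen-bond acceptor that 4-methylphenyl lacks, yet inhibition remains far from that of compound 1. The steps from compound 2 and compound 3 to compound 4 cannot be read because the values of compound 2 and compound 3 are limits: the limit of > 30000 nM in this assay, at which 2 of the 4 values shown sit.

From the compounds shown here alone, whether chloro or an amine in place of bromo would match compound 1 remains open.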